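This account rests on a few compounds, and the source may have more. Where it says the series, first, only, none or still open, it means among the compounds named here.

Four compounds share a benzyloxy-bearing aromatic ring joined to a five-membered ring, and they were tested in a functional assay on A549 cells (Homo sapiens) for inhibition, read by sulforhodamine B assay; a lower number here means a stronger inhibitor of growth, a higher number a weaker inhibitor of growth. Compound 1 `COc1ccc(OCc2ccccc2)c(/C=C2\SC(=S)NC2=O)c1` gives 7000 nM in this assay. Compound 2 `O=C1NC(=S)S/C1=C\c1cc([N+](=O)[O-])ccc1OCc1ccccc1` has a nitro group in place of the methoxy group of compound 1 (nitro in place of methoxy on an aromatic carbon). In this assay compound 2 gives 5000 nM, a step of a 1.4-fold lower number from compound 1 to compound 2 (0.15 log units; within the scatter). Compound 3 `COc1ccc(OCc2ccccc2)c(/C=C2\SC(=O)NC2=O)c1` carries a different five-membered ring than compound 1 (a group of 8 heavy atoms (4 carbon, 1 nitrogen, 2 oxygen, 1 sulfur; one five-membered non-aromatic ring with 2 hetero atoms) in place of a group of 8 heavy atoms (4 carbon, 1 nitrogen, 1 oxygen, 2 sulfur; one five-membered non-aromatic ring with 2 hetero atoms), on an aromatic carbon). In this assay compound 3 gives 14000 nM, a step of a 2.0-fold higher number from compound 1 to compound 3 (0.30 log units; within the scatter).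

Compound 4 `O=C1NC(=O)/C(=C/c2cc([N+](=O)[O-])ccc2OCc2ccccc2)S1` has not yet been measured. It stands to compound 3 as compound 2 stands to compound 1: the change is nitro in place of methoxy on an aromatic carbon, and since the surroundings of the changed position are described in the same words for both pairs, it is the same change made on a different core. Among the measured compounds shown here, the only guide to its effect is the step from compound 1 to compound 2, which was small. On that basis the step from compound 3 to compound 4 in this assay is expected to be about a 1.4-fold lower number from compound 3 to compound 4 (0.15 log units; within the scatter), resting on a 1.4-fold lower number from compound 1 to compound 2 (0.15 log units; within the scatter) and on compound 3 giving 14000 nM. Compound 4 is therefore estimated to give about 10000 nM in this assay, with a plausible range from 4000 nM to 25000 nM.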

Compound 4, concentration for 50% growth inhibition: 14000 nM
For compound 4 the middle estimate is 1.4-fold (0.15 log units) below the measured one; measured number inside the range.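

Putting nitro in place of methoxy on the core of compound 3 gives no change at the digits printed from compound 3 to compound 4 (within the scatter) in this assay, so this change behaves alike on the two cores: the same change on two cores in this assay, a 1.4-fold lower number (0.15 log units; within the scatter) from compound 1 to compound 2 and no change at the digits printed (within the scatter) from compound 3 to compound 4, 1.4-fold (0.15 log units) apart, within the scatter of two such steps. The exchange of the five-membered ring, made with nitro on the aromatic ring, gives a 2.8-fold higher number from compound 2 to compound 4 (0.45 log units; beyond the scatter), and this agrees with the same exchange made with methoxy there: the same change on two cores in this assay, a 2.0-fold higher number (0.30 log units; within the scatter) from compound 1 to compound 3 and a 2.8-fold higher number (0.45 log units; beyond the scatter) from compound 2 to compound 4, 1.4-fold (0.15 log units) apart, within the scatter of two such steps. This agreement is only a weak test of carrying a change from one core to another, since two steps that are both within the scatter will readily match, and it rests on a single pair of compounds for each core, so it does not show that the nitro change would behave alike on any further core or in any other assay.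

The compounds shown leave open whether a group other than methoxy or nitro at this place on the aromatic ring, such as an amine or a carboxylic acid, would give a larger step on either core. They also leave open what would follow if the benzyloxy group gave way to a simple alkyl chain, or if a methyl group took the place of the amide hydrogen in the five-membered ring.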